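Cyclohexyl on the ring amine of compound 1

The compounds below may be only part of what the source reports. "The series", "measured", "known", "first", "only" and "open" are said of these compounds alone.

Values so far in a physicochemical assay for lipophilicity, at pH 7.4 (a higher number here means a more lipophilic compound, a lower number a more polar compound), for two compounds:
- compound 1 `CC(C)(C)CCNc1cc(N2CCNCC2)ncn1` gives 1.4
- compound 2 `CN1CCCN(c2cc(NCC(C)(C)C)ncn2)CC1` gives 0.96

Compound 1 stands highest of these two numbers, with compound 2 lower by a gap beyond the scatter. Compound 3 `CC(C)(C)CCNc1cc(N2CCN(C3CCCCC3)CC2)ncn1` has cyclohexyl in place of hydrogen on an amine nitrogen in a ring and otherwise matches compound 1. Among the measured compounds shown here, no measured pair covers this change, so the size is a judgement. A large upward change in this assay is expected, well beyond the scatter, and the estimated step is a number 1.80 log units higher from compound 1 to compound 3 (beyond the scatter) for this change. The estimate for compound 3 is 3.2 with an expected range (2.5 to 3.9).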

Compound 3, distribution coefficient: 3.84
Compound 3: middle estimate off by 0.64 log units, on the low side; the measured number falls inside the stated range.
By their numbers in this assay, from the lowest: compound 2; then compound 1; then compound 3.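

In this assay, the ring amine nitrogen of compound 1 now has its first measured step: cyclohexyl in place of hydrogen gives a number 2.44 log units higher from compound 1 to compound 3 (beyond the scatter) and is classed as large. Among the compounds shown here, the earlier compounds differ in more than one place and gave no step, so this is the first evidence that a single change at this nitrogen can move the number this far. No measurement in hand explains the size of this step.

On these data alone, whether phenyl or isopropyl on the same nitrogen would give a similar step remains open. So does the effect of a carboxylic acid or an amine on the cyclohexyl ring.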